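The source may hold more compounds than are shown below. What is called first, only, known or untested is meant among the compounds shown, and "the series" means these compounds.

Compounds measured in a functional assay on KM12 cells (Homo sapiens) for cytotoxicity, read by sulforhodamine B assay, with a stated time of 24 h; a higher number here means a weaker inhibitor of growth, a lower number a stronger inhibitor of growth:
compound 1, `COc1ccc(C(=O)/C=C/c2cc3ccccc3[nH]c2=O)cc1`, in this assay gives 2850 nM
compound 2, `O=C(/C=C/c1cc2ccccc2[nH]c1=O)c1ccc(O)cc1`, in this assay gives 1890 nM

For the measured compounds named here, compound 2 holds the lower of the two numbers, but the only measured step, a 1.5-fold lower number from compound 1 to compound 2 (0.18 log units; within the scatter), stays within the scatter, so the two are not separated. Compound 3, `O=C(/C=C/c1cc2ccccc2[nH]c1=O)c1ccc(Cl)cc1`, differs from compound 2 by chloro in place of hydroxy on an aromatic carbon. Going by the values given here, no measured step exchanges a hydroxy for a chloro; the single step measured touches the same aromatic carbon and moved nothing beyond the scatter, so no step beyond the scatter is expected here either. Compound 3 is expected at 2000 nM, with a range from 800 nM to 5000 nM. The expected step is a 1.1-fold higher number from compound 2 to compound 3 (0.02 log units; within the scatter).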

Compound 3, concentration for 50% growth inhibition: 3230 nM
Estimate against measurement, compound 3: 1.6-fold (0.21 log units) below; the measured number falls inside the stated range.
By their numbers in this assay, from the lowest: compounds 2, 1 and 3 (each within the scatter of the next).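

In this assay chloro on this aromatic carbon, para to a large group, joins hydroxy and methoxy: the exchange for hydroxy gives a 1.7-fold higher number from compound 2 to compound 3 (0.23 log units; within the scatter) and the exchange for methoxy gives a 1.1-fold higher number from compound 1 to compound 3 (0.05 log units; within the scatter) so all three groups remain unseparated. Replacing hydroxy with chloro removes the hydrogen-bond donor and acceptor counted on hydroxy, yet compound 3 stays within the scatter of compound 2. No evidence bears on this result.

Open, as far as these compounds go, is whether any group here moves the number beyond the scatter, such as an amine, a carboxylic acid or a longer chain. Also open, from the compounds shown here alone, is whether chloro behaves alike elsewhere on this ring.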